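A few compounds are considered here, and "the series" means these few. Any claim that something is new, unique, unknown or untested is made for them only; others in the source may bear on it.

Compound 1 `COC(=O)c1sc2c(C)cccc2c1Nc1cc(OC)c(OC)c(OC)c1`: 1630 nM
Compound 2 `COC(=O)c1sc2ncccc2c1Nc1cc(OC)c(OC)c(OC)c1`: 1110 nM

Among the compounds with values here, in a functional assay on Jurkat cells (Homo sapiens) for cytotoxicity, read by MTT assay, with a stated time of 72 h (a lower number here means a stronger inhibitor, a higher number a weaker inhibitor), compound 1 gives 1630 nM, which lies within the scatter of the value for compound 2, the only other measured compound. Compound 3 `COC(=O)c1sc2ccccc2c1Nc1cc(OC)c(OC)c(OC)c1` is not yet measured and differs from compound 1 at one place: hydrogen in place of methyl on an aromatic carbon. This puts hydrogen in place of methyl on an aromatic carbon. Within the data shown here, no measured pair shows a step of this kind, so nothing firm indicates a direction. The expected change is no more than the scatter, a 1.3-fold lower number from compound 1 to compound 3 (0.10 log units; within the scatter). For compound 3 the estimated value is 1300 nM, with an expected range of 500 nM to 3400 nM.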

Compound 3, half-maximal inhibitory concentration: 490 nM
The estimate for compound 3 lay 2.7-fold (0.42 log units) above the measured number; the measured number lies below the stated range.
By their numbers in this assay, from the lowest: compound 3; then compounds 2 and 1 (each within the scatter of the next).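

In this assay the change from methyl to hydrogen on this aromatic carbon gives a 3.3-fold lower number from compound 1 to compound 3 (0.52 log units; beyond the scatter) and so counts as a modest step. The earlier compounds shown here did not show that this carbon of the core affects the value; in this pair, methyl gives the higher number and hydrogen the lower. Nothing measured here explains the step. As far as these compounds go, whether the higher number is specific to methyl remains open. Fluorine, chlorine, a methoxy group or an ethyl chain on this carbon would test that.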